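From 2-fluorophenyl to 4-aminophenyl on the shared core

The compounds below may be only part of what the source reports. "The series", "measured", "known", "first", "only" and "open" are said of these compounds alone.

In a functional assay on SGC-7901 cells (Homo sapiens) for antiproliferative activity, read by MTT assay, with a stated time of 48 h (on this read-out higher numbers stand for weaker inhibition and lower numbers for stronger inhibition), compound 2 `Fc1ccccc1-c1nnc(SCc2ccc(Cl)nc2)o1` gives 9.12 ug/mL, the higher of the two actual numbers, and compound 1 `COc1ccc(-c2nnc(SCc3ccc(Cl)nc3)o2)cc1` gives 3.5 ug/mL. Compound 3 `Oc1ccc(-c2nnc(SCc3ccc(Cl)nc3)o2)cc1` reads > 20 ug/mL, which is a limit and not a number. Compound 4 `Nc1ccc(-c2nnc(SCc3ccc(Cl)nc3)o2)cc1` differs from compound 2 as follows: 4-aminophenyl in place of 2-fluorophenyl on an aromatic carbon. Within the data shown here, two measured steps bear on this change. The closer one, with 4-hydroxyphenyl in place of 2-fluorophenyl, is an at least 2.1-fold higher number from compound 2 to compound 3 (0.34 log units; beyond the scatter). The other, with hydrogen in place of methyl on an oxygen, is an at least 5.7-fold higher number from compound 1 to compound 3 (0.75 log units; beyond the scatter). A small move toward a higher number is therefore expected in this assay: a 1.6-fold higher number from compound 2 to compound 4 (0.22 log units; within the scatter). For compound 4 the estimated value is 15 ug/mL, with an expected range from 5 ug/mL to 30 ug/mL.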

Compound 4, half-maximal inhibitory concentration: 8.48 ug/mL
The estimate for compound 4 lay 1.8-fold (0.25 log units) above the measured number; the range from low to high includes it.
By their numbers in this assay, from the lowest: compound 1; then compounds 4 and 2 (each within the scatter of the next). At a limit, above all of these: compound 3.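

In this assay, the step of a 1.1-fold lower number from compound 2 to compound 4 (0.03 log units; within the scatter) does not separate 4-aminophenyl from 2-fluorophenyl on this aromatic carbon, whereas a 2.4-fold higher number from compound 1 to compound 4 (0.38 log units; beyond the scatter) shows that amino in place of methoxy does count. Compound 3 stands at a limit and not at a number, so an at least 2.3-fold lower number from compound 3 to compound 4 (0.37 log units; beyond the scatter) is a bound on the change from hydroxy to amino: (the limit of > 20 ug/mL in this assay, at which 1 of the 4 values shown sits).

From the compounds shown here alone, whether a dimethylamino or acetamido group in place of amino stays close to compound 4 remains open. So does the effect of a carboxylic acid on the same phenyl ring.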